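Reversing one double bond: from compound 2 to compound 3

The source may hold more compounds than are shown below. What is called first, only, known or untested is meant among the compounds shown, and "the series" means these compounds.

Compound 1 `C=C(Br)C(=O)Nc1ccc2c(c1)/C(=C\c1ccc(C)s1)C(=O)N2`: 20 nM
Compound 2 `C=C(Br)C(=O)Nc1ccc2c(c1)/C(=C\c1sccc1C)C(=O)N2`: 4 nM

In a functional assay on RS4-11 cells (Homo sapiens) for antiproliferative activity, read by MTT assay, with a stated time of 72 h (on this read-out lower numbers stand for stronger inhibition and higher numbers for weaker inhibition), compound 2 has the lower of the two numbers, and the gap to compound 1 lies beyond the scatter. Among the compounds with values here, the only measured step, a 5.0-fold lower number from compound 1 to compound 2 (0.70 log units; beyond the scatter), comes with 3-methylthiophen-2-yl in place of 5-methylthiophen-2-yl on a double-bonded chain carbon bound to a double-bonded ring carbon. It is a modest step.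

Compound 3 `C=C(Br)C(=O)Nc1ccc2c(c1)/C(=C/c1sccc1C)C(=O)N2` has not yet been measured. The structural change is this: the two compounds have the same atoms and bonds and differ only in configuration as drawn: 1 of 1 stereo elements differ; a double bond is drawn E in compound 2 and Z in compound 3. Within the data shown here, no measured step tests a change of configuration, so the data give only a rough guide to its size. The step to compound 2, a 5.0-fold lower number from compound 1 to compound 2 (0.70 log units; beyond the scatter), shows that a change in this part of the structure can move the number beyond the scatter. Among the measured compounds shown here, compound 2 stands at the low end of the numbers so far, so a rise of similar size is expected, with wide uncertainty. The expected step is a 3.0-fold higher number from compound 2 to compound 3 (0.48 log units; beyond the scatter). In this assay, compound 3 is estimated at 12 nM, with an expected range from 3 nM to 50 nM.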

Compound 3, half-maximal inhibitory concentration: 0.4 nM
The estimate for compound 3 lay 30-fold (1.48 log units) above the measured number, and the stated range ends above it.
By their numbers in this assay, from the lowest: compound 3; then compound 2; then compound 1.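

The result shows that the geometry of this double bond can, by itself, move the number beyond the scatter in this assay: with nothing entering or leaving, the reversal gives a 10-fold lower number from compound 2 to compound 3 (1.00 log units; beyond the scatter). Within the data shown here, the earlier step, a 5.0-fold lower number from compound 1 to compound 2 (0.70 log units; beyond the scatter), spoke only to where the methyl sits on the thiophene, so the double bond now stands as a second place in these compounds where the number responds, and the lowest value so far comes with the Z drawing. The shift can be tied to the double bond alone because of this: the fact that compounds 2 and 3 differ only in the configuration as drawn.

What remains open is whether the same reversal would lower the number to a similar degree with the 5-methylthiophen-2-yl group of compound 1, since the compounds shown give this comparison for the 3-methylthiophen-2-yl group alone. From the compounds shown here alone, it is also open whether the Z drawing would keep its advantage with an ethyl group in place of the methyl or with a phenyl ring in place of the thiophene, or in any cell line other than the one used here.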